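The source may hold more compounds than are shown below. What is called first, only, known or untested is meant among the compounds shown, and "the series" means these compounds.

Measured so far:
compound 1, `CCCc1nc2cccc(C(=O)O)c2n1Cc1ccc(-c2ccccc2-c2noc(O)n2)cc1` — 100% in a functional assay on the whole organism for inhibition, with Rattus norvegicus as the target, with a stated time of 3 h, at a dose of 1 mg/kg by the oral route; a higher number here means more inhibition at the dose given (going by the name of the read-out), a lower number less inhibition
compound 2, `CCCCc1nc2cccc(C(=O)O)c2n1Cc1ccc(-c2ccccc2-c2noc(O)n2)cc1` — 68%
compound 3, `CCCOc1nc2cccc(C(=O)O)c2n1Cc1ccc(-c2ccccc2-c2noc(O)n2)cc1` — 100%

Compound 3 stands level with compound 1, and together they give the two highest of the three numbers; the step of no change at the digits printed from compound 1 to compound 3 (within the scatter) is within the scatter. Compound 2 sits apart: the step of a number 32 percentage points higher from compound 2 to compound 3 (beyond the scatter) is large, as is a number 32 percentage points lower from compound 1 to compound 2 (beyond the scatter).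

Compound 4, `CCSc1nc2cccc(C(=O)O)c2n1Cc1ccc(-c2ccccc2-c2noc(O)n2)cc1`, is the next member to be measured in this assay. Its change from compound 3 is ethylsulfanyl in place of propoxy on an aromatic carbon.

Among the measured compounds shown here, none of the measured steps exchanges oxygen for sulfur, so no step bears on it directly. For the measured compounds named here, the nearest guide is the pair of compounds 1 and 3, where propoxy for propyl left the number unchanged within the scatter, while the one step that lowered the number, from compound 1 to compound 2, added a carbon to the chain. Ethylsulfanyl carries one heavy atom fewer than propoxy, so a large fall is not expected; with compound 3 already at the top of the range, the only room is downward.

Compound 4 is therefore expected to give about 88%, between 60% and 100%. The step of a number 12 percentage points lower from compound 3 to compound 4 (beyond the scatter) is estimated to stay within or close to the scatter.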

Compound 4, a percentage reported as inhibition, in the whole organism at one dose (the size of the read-out at that dose, not a potency): 83%
For compound 4 the middle estimate is 5 percentage points above the measured one; low and high end bracket the measured number.
By their numbers in this assay, from the lowest: compound 2; then compound 4; then compounds 1 and 3 (each within the scatter of the next).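

In this assay, ethylsulfanyl in place of propoxy gives a number 17 percentage points lower from compound 3 to compound 4 (beyond the scatter), and ethylsulfanyl in place of propyl gives a number 17 percentage points lower from compound 1 to compound 4 (beyond the scatter), so on this aromatic carbon, between two ring nitrogen atoms, the propyl and propoxy result does not extend to ethylsulfanyl. Ethylsulfanyl in place of butyl gives a number 15 percentage points higher from compound 2 to compound 4 (beyond the scatter), which sets compound 4 apart both from compound 2 and from the pair of compounds 1 and 3. No measurement on hand accounts for these steps.

Open, from the compounds shown here alone, is whether propylsulfanyl, with the chain of propoxy, would stand with compound 3 or with compound 4, which would separate the sulfur from the shorter chain. Also open, going by these compounds, is how an amine such as propylamino would behave on this carbon, and any order between compounds 1 and 3 at a lower dose.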